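Urea for cyclic urea, tried a second time

The source may report more compounds than this note shows. Statements on the series, on what has been measured and on what is new or still open speak of the compounds shown alone.

Compound 1 `Cc1cc(C)cc(/C=C/c2ccc(N3CCNC3=O)cc2)c1`: 14000 nM
Compound 2 `CCNC(=O)Nc1ccc(/C=C/c2cc(OC)c(OC)c(OC)c2)cc1`: 12000 nM
Compound 3 `COc1cc(/C=C/c2ccc(N3CCNC3=O)cc2)cc(OC)c1OC`: 370 nM

Three stilbene compounds have been measured in a functional assay on HT-29 cells (Homo sapiens) for inhibition, read by sulforhodamine B assay, with a stated time of 48 h; on this read-out higher numbers stand for weaker inhibition and lower numbers for stronger inhibition. Compound 3 gives 370 nM, compound 2 gives 12000 nM, and compound 1 gives 14000 nM. Among the measured compounds shown here, the only single-point change among them runs from compound 3 to compound 2: (ethylcarbamoyl)amino in place of 2-oxoimidazolidin-1-yl on an aromatic carbon It brought a 32-fold higher number from compound 3 to compound 2 (1.51 log units; beyond the scatter).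

Compound 4 `CCNC(=O)Nc1ccc(/C=C/c2cc(C)cc(C)c2)cc1` has not been measured. It carries the same change, applied to the core of compound 1: (ethylcarbamoyl)amino in place of 2-oxoimidazolidin-1-yl on an aromatic carbon How the core of compound 1 differs from that of compound 3 is not broken down here; what is seen is that compound 1 and compound 3 differ beyond the scatter, while compound 1 and compound 2 lie within the scatter of each other.

For compound 4 a step of about a 4.3-fold higher number from compound 1 to compound 4 (0.63 log units; beyond the scatter) in this assay is expected, smaller than the earlier one, because compound 1 already stands at 14000 nM, the highest of the three measured numbers. Compound 4 is therefore estimated at 60000 nM, with a range from 15000 nM to 300000 nM.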

Compound 4, half-maximal inhibitory concentration: > 20000 nM
Compound 4: only a limit was reported; the forecaster's own chance of this, stated with the estimate: 40%; the middle value does not contradict the limit.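

In this assay compound 4 gives > 20000 nM, which is a limit of the assay and not a number. Putting (ethylcarbamoyl)amino in place of 2-oxoimidazolidin-1-yl on the core of compound 1 gives an at least 1.4-fold higher number from compound 1 to compound 4 (0.15 log units; that floor lies within the scatter), so the result fits a rise in the number like the one on the core of compound 3 but does not by itself show a rise beyond the scatter. It therefore does not show whether the change carries over between these two cores with the same size: the same change on two cores in this assay, a 32-fold higher number (1.51 log units; beyond the scatter) from compound 3 to compound 2 and an at least 1.4-fold higher number (0.15 log units; that floor lies within the scatter) from compound 1 to compound 4; the limit leaves it open whether they differ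

The compounds shown leave open what a methyl or a longer chain in place of the ethyl on the open urea would give on either core, and what a plain amine in place of the whole urea would give. They also leave open how far the number of compound 4 lies past its limit.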